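Aryl Replacement on the Benzyl Ring of Compound 3

This account rests on a few compounds, and the source may have more. Where it says the series, first, only, none or still open, it means among the compounds named here.

Measured compounds:
compound 1, `COC(=O)/C=C/c1cccc(N(Cc2ccc(-c3ccc(F)c(Cl)c3)cc2)C(=O)C2CCCCC2)c1`, gives 66 nM in an assay on isolated protein with Bile acid receptor (Homo sapiens) as the target; a lower number here means that less compound is needed, a higher number that more compound is needed for the effect
compound 2, `COC/C=C/c1ccc(CN(C(=O)C2CCCCC2)c2cccc(/C=C/C(=O)OC)c2)cc1`, gives 233 nM in this assay
compound 3, `COC(=O)/C=C/c1cccc(N(Cc2ccc(/C=C/C(=O)O)cc2)C(=O)C2CCCCC2)c1`, reaches only the limit > 1000 nM in this assay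

For the measured compounds named here, compound 3 thus stands at the bottom of the three: its result is a limit of the assay and not a number, and it is the one value of the three that sits at the limit of > 1000 nM in this assay, at which 1 of the 3 values shown sits. Its step down from compound 1 was an at least 15-fold higher number from compound 1 to compound 3 (1.18 log units; beyond the scatter), and from compound 2 it was an at least 4.2-fold higher number from compound 2 to compound 3 (0.63 log units; beyond the scatter), both beyond the scatter.

Compound 4, `COC(=O)/C=C/c1cccc(N(Cc2ccc(-c3ccc(OC(F)(F)F)cc3)cc2)C(=O)C2CCCCC2)c1`, differs from compound 3 in one place: 4-(trifluoromethoxy)phenyl in place of 2-carboxyethenyl on an aromatic carbon. The step from compound 1 to compound 3 bears most directly on this change, since compound 1 also carries a substituted phenyl ring on that aromatic carbon, and it was large. Reversing a step of that size leads to the expectation of a large fall in the number for compound 4 in this assay, estimated as an at least 12-fold lower number from compound 3 to compound 4 (1.09 log units; beyond the scatter). Compound 4 is therefore expected to give about 80 nM, within a range from 30 nM to 300 nM.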

Compound 4, half-maximal effective concentration: 264 nM
Beside the measured number, compound 4's estimate is 3.3-fold (0.52 log units) below it; low and high end bracket the measured number.
By their numbers in this assay, from the lowest: compound 1; then compounds 2 and 4 (each within the scatter of the next). At a limit, above all of these: compound 3.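

Compound 3 remains a limit of the assay and not a number: the limit of > 1000 nM in this assay, at which 1 of the 4 values shown sits.

Against that limit, 4-(trifluoromethoxy)phenyl on this aromatic carbon gives an at least 3.7-fold lower number from compound 3 to compound 4 (0.57 log units; beyond the scatter) in this assay, yet a substituted phenyl ring here does not by itself match compound 1, as the exchange of 3-chloro-4-fluorophenyl for 4-(trifluoromethoxy)phenyl gives a 4.0-fold higher number from compound 1 to compound 4 (0.60 log units; beyond the scatter). The position therefore separates two substituted phenyl rings, while the ring of compound 4 and the open 3-methoxyprop-1-en-1-yl chain of compound 2 cannot be told apart, with a 1.1-fold higher number from compound 2 to compound 4 (0.05 log units; within the scatter).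

The compounds shown leave open which part of the 3-chloro-4-fluorophenyl ring sets compound 1 apart from compound 4, since the two rings share no substituent; a phenyl ring carrying only a chlorine or only a fluorine would separate those contributions. They also leave open whether the carboxylic acid itself or the whole 2-carboxyethenyl chain accounts for the result of compound 3, which a methyl ester or a saturated carboxyethyl chain at the same place could address.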